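The compounds below may be only part of what the source reports. "The series", "measured", "known", "first", "only" and "open" are said of these compounds alone.

Three compounds of the series have been measured in a physicochemical assay for solubility, read by HPLC, at pH 7; a higher number here means a more soluble compound, a lower number a less soluble compound:

compound 1 `O=[N+]([O-])c1cn2c(n1)OC[C@@H](OCC#Cc1ccc(OCc3ccccc3)cc1)C2`: 0.43 ug/mL
compound 2 `O=[N+]([O-])c1cn2c(n1)OC[C@@H](OCC#Cc1ccc(-c3ccc(OC(F)(F)F)cc3)cc1)C2`: 0.07 ug/mL
compound 3 `O=[N+]([O-])c1cn2c(n1)OC[C@@H](OC/C=C/c1ccc(-c3ccc(OC(F)(F)F)cc3)cc1)C2`: 0.5 ug/mL

Compound 2 and compound 1 differ in one place, namely (benzyloxy in place of 4-(trifluoromethoxy)phenyl on an aromatic carbon). In this assay this gives a 6.1-fold higher number from compound 2 to compound 1 (0.79 log units; beyond the scatter).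

Compound 3 has the highest of the three numbers. Its gap to compound 1 is within the scatter, so no order between these two is claimed; its gap to compound 2 is beyond the scatter. Compound 3 and compound 2 differ in more than one place, and the difference between the two cores is not broken down here.

Compound 4 `O=[N+]([O-])c1cn2c(n1)OC[C@@H](OC/C=C/c1ccc(OCc3ccccc3)cc1)C2` has not yet been measured in this assay. It differs from compound 3 by benzyloxy in place of 4-(trifluoromethoxy)phenyl on an aromatic carbon. The place of this change is described word for word as it is for the change from compound 2 to compound 1, so it is the same change, made a second time in the series, now on the core of compound 3.

Going by the values given here, for compound 4 the step from compound 3 is expected to be a 6.0-fold higher number from compound 3 to compound 4 (0.78 log units; beyond the scatter) in this assay, set beside a 6.1-fold higher number from compound 2 to compound 1 (0.79 log units; beyond the scatter); this rests on that single measured pair, because a 6.1-fold higher number from compound 2 to compound 1 (0.79 log units; beyond the scatter) is the only occurrence of the change with numbers on both sides, and the value of compound 3, 0.5 ug/mL, is the starting point. The wide range reflects that one pair alone carries the expectation.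

Compound 4 is therefore estimated at 3 ug/mL, expected to fall between 1 ug/mL and 8 ug/mL.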

Compound 4, solubility: 0.06 ug/mL
Beside the measured number, compound 4's estimate is 50-fold (1.70 log units) above it; the measured number lies below the stated range.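

In this assay the change to benzyloxy in place of 4-(trifluoromethoxy)phenyl on an aromatic carbon gives an 8.3-fold lower number from compound 3 to compound 4 (0.92 log units; beyond the scatter) on the core of compound 3, whereas on the core of compound 2 it gives a 6.1-fold higher number from compound 2 to compound 1 (0.79 log units; beyond the scatter) as the earlier step, so the two occurrences of one change lie beyond the scatter and run in opposite directions. The direction of this change therefore did not carry from one core to the other, and in this series a step read on one core cannot be taken as a guide to the same step on the other. Two pairs show only that the outcome of the change differs with the core and give no rule for which core yields which direction, and nothing measured here accounts for the reversal.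

On these data alone, whether the change follows the step on the core of compound 2 or the step on the core of compound 3 on any further core remains open. Also open is how this assay would read with an amine or a carboxylic acid in place of benzyloxy or 4-(trifluoromethoxy)phenyl, since neither group occurs among the compounds shown.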